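From 4-methoxyphenyl to 2-chlorophenyl on a shared core

The compounds below may be only part of what the source reports. "The series", "measured", "known", "first", "only" and "open" are said of these compounds alone.

Values in a functional assay on CaEs17 cells (Homo sapiens) for cytotoxicity, read by MTT assay, with a stated time of 72 h; on this read-out higher numbers stand for weaker inhibition and lower numbers for stronger inhibition:
Compound 1 `C=C1C(=O)[C@@]23C(=O)OC[C@]4(C(=O)CCC(C)(C)[C@H]4C=O)[C@@H]2CC[C@@H]1[C@H]3OC(=O)CC`: 1400 nM
Compound 2 `C=C1C(=O)[C@@]23C(=O)OC[C@]4(C(=O)CCC(C)(C)[C@H]4C=O)[C@@H]2CC[C@@H]1[C@H]3OC(=O)c1ccc(C)cc1`: 1050 nM
Compound 3 `C=C1C(=O)[C@@]23C(=O)OC[C@]4(C(=O)CCC(C)(C)[C@H]4C=O)[C@@H]2CC[C@@H]1[C@H]3OC(=O)c1ccc(OC)cc1`: 2980 nM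

Compound 3 has the highest number of the three, and so the weakest inhibition. Compound 4 `C=C1C(=O)[C@@]23C(=O)OC[C@]4(C(=O)CCC(C)(C)[C@H]4C=O)[C@@H]2CC[C@@H]1[C@H]3OC(=O)c1ccccc1Cl` keeps the shared core but carries 2-chlorophenyl in place of 4-methoxyphenyl on a carbonyl carbon. Within the data shown here, no compound with chlorine has been measured, so the evidence is indirect. With a 2.1-fold higher number from compound 1 to compound 3 (0.33 log units; beyond the scatter) and a 2.8-fold higher number from compound 2 to compound 3 (0.45 log units; beyond the scatter) both modest but beyond the scatter, compound 3 sits apart, whereas a 1.3-fold lower number from compound 1 to compound 2 (0.12 log units; within the scatter) stays within it. Losing the 4-methoxyphenyl is therefore expected to bring a modest fall in this assay, an estimated 2.0-fold lower number from compound 3 to compound 4 (0.30 log units; within the scatter). For compound 4 the expected value is 1500 nM, with an estimated range of 750 nM to 3000 nM.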

Compound 4, half-maximal inhibitory concentration: 2010 nM
Estimate against measurement, compound 4: 1.3-fold (0.13 log units) below; the measured number falls inside the stated range.
By their numbers in this assay, from the lowest: compounds 2, 1, 4 and 3 (each within the scatter of the next, the first and the last beyond it).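

In this assay, 2-chlorophenyl on this carbonyl carbon cannot be told apart from any group before it, with a 1.5-fold lower number from compound 3 to compound 4 (0.17 log units; within the scatter), a 1.9-fold higher number from compound 2 to compound 4 (0.28 log units; within the scatter) and a 1.4-fold higher number from compound 1 to compound 4 (0.16 log units; within the scatter). This position therefore takes a chlorine-bearing aromatic ring with no step beyond the scatter, and compound 4 bridges the gap that had set compound 3 apart from compound 2. No supporting data bear on why this is so. Still open, from the compounds shown here alone, is whether 4-chlorophenyl would read like 2-chlorophenyl, and how an aminomethylphenyl group or a longer chain would read at this carbonyl carbon.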